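Pyrimidine for methylpyrazine on a second core

A few compounds are considered here, and "the series" means these few. Any claim that something is new, unique, unknown or untested is made for them only; others in the source may bear on it.

Compound 1 `COc1cc(NC(=O)c2cnc(C)cn2)c2ncccc2c1` carries a 5-methylpyrazin-2-yl group on the amide carbonyl. In a functional assay on PANC-1 cells (Homo sapiens) for inhibition, read by MTT assay, with a stated time of 72 h (on this read-out higher numbers stand for weaker inhibition and lower numbers for stronger inhibition), compound 1 gives 800 nM. Compound 2 `COc1cc(NC(=O)c2ncccn2)c2ncccc2c1` differs from it by pyrimidin-2-yl in place of 5-methylpyrazin-2-yl on a carbonyl carbon and in this assay compound 2 gives 9000 nM. The step is an 11-fold higher number from compound 1 to compound 2 (1.05 log units; beyond the scatter).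

Compound 3 `Cc1cnc(C(=O)Nc2cc(OCCNC(=O)OC(C)(C)C)cc3cccnc23)cn1` keeps the 5-methylpyrazin-2-yl amide, but its core differs from the core of compound 1 by ((tert-butoxycarbonyl)amino)methyl in place of hydrogen on a saturated chain carbon bound to an oxygen on an aromatic ring. In this assay compound 3 gives 2170 nM, the step being a 2.7-fold higher number from compound 1 to compound 3 (0.43 log units; beyond the scatter). Among the three measured compounds compound 3 stands second highest, nearest to compound 1 and furthest from compound 2.

Compound 4 `CC(C)(C)OC(=O)NCCOc1cc(NC(=O)c2ncccn2)c2ncccc2c1` is not yet measured. It differs from compound 3 by pyrimidin-2-yl in place of 5-methylpyrazin-2-yl on a carbonyl carbon. The place of this change reads the same word for word as in the pair of compound 1 and compound 2, so it is the same change carried onto the core of compound 3. For the measured compounds named here, only one earlier instance of the change exists, so any expectation rests on that single pair. For compound 4 the expected step is an 11-fold higher number from compound 3 to compound 4 (1.04 log units; beyond the scatter), because the same change already gave an 11-fold higher number from compound 1 to compound 2 (1.05 log units; beyond the scatter). Whether the core change and the amide change add together is not shown by the compounds in hand. Compound 4 is expected to give 24000 nM in this assay, estimated to fall between 8000 nM and 70000 nM.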

Compound 4, half-maximal inhibitory concentration: > 10000 nM
Compound 4 was reported as a limit; the forecaster's own chance of this, stated with the estimate: 20%; the middle value lies beyond the limit too.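

In this assay compound 4 is reported only as a limit, > 10000 nM, and not as a number. Pyrimidin-2-yl in place of 5-methylpyrazin-2-yl on a carbonyl carbon again moves the number upward on the second core, with an at least 4.6-fold higher number from compound 3 to compound 4 (0.66 log units; beyond the scatter), so the direction of the step carries from the core of compound 1 to the core of compound 3, but its size on the second core remains unknown and no equality of the two steps is shown: the same change on two cores in this assay, an 11-fold higher number (1.05 log units; beyond the scatter) from compound 1 to compound 2 and an at least 4.6-fold higher number (0.66 log units; beyond the scatter) from compound 3 to compound 4; the limit leaves it open whether they differ

The core change read on the pyrimidin-2-yl amides gives an at least 1.1-fold higher number from compound 2 to compound 4 (0.04 log units; that floor lies within the scatter), so these compounds do not show whether the step seen with the 5-methylpyrazin-2-yl amide recurs there, nor whether the two changes add: the same change on two cores in this assay, a 2.7-fold higher number (0.43 log units; beyond the scatter) from compound 1 to compound 3 and an at least 1.1-fold higher number (0.04 log units; that floor lies within the scatter) from compound 2 to compound 4; the limit leaves it open whether they differ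

The direction of the amide change rests on only two cores, and the compounds shown leave open whether it would hold on a core with a free amine or a longer chain in place of the ((tert-butoxycarbonyl)amino)methyl group. An unsubstituted pyrazin-2-yl amide would be needed to separate the methyl group from the change of ring, since the present change alters both at once.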